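A few compounds are considered here, and "the series" means these few. Any claim that something is new, unique, unknown or untested is made for them only; others in the source may bear on it.

Measured compounds:
compound 1 `CCCCCc1nc(-c2ccc(CNC(=O)[C@H]3NCC[C@@H]3O)cc2)no1`, 430 nM
compound 2 `CCCCCCCc1nnc(-c2ccc(CNC(=O)[C@H]3NCC[C@@H]3O)cc2)o1`, 2200 nM

Of the compounds shown here, two have been measured in an assay on isolated protein for inhibition of sphingosine kinase 1 (Homo sapiens); on this read-out higher numbers stand for weaker inhibition and lower numbers for stronger inhibition. Compound 1 gives 430 nM, the lower of the two numbers. Compound 2 gives 2200 nM, a higher number, and the gap between the two is beyond the usual scatter, so compound 1 is the stronger inhibitor of the pair. Compound 2 differs from compound 1 in more than one place, so no single structural step can be read from it.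

The third compound, compound 3 `CCCCCCCCc1nc(-c2ccc(CNC(=O)[C@H]3NCC[C@@H]3O)cc2)no1`, has not been measured in this assay. It differs from compound 1 in one place: propyl in place of hydrogen on a saturated chain carbon, five bonds along the chain from an aromatic carbon. Among the measured compounds shown here, nothing among the measured compounds shows a change of this kind on the shared core, so the size and direction of the step are open. The chain is lengthened by three carbons; such a change is expected to move the number only moderately in this assay, with a slight lean toward a higher number. The step of a 1.4-fold higher number from compound 1 to compound 3 (0.14 log units; within the scatter) is the expected outcome. Compound 3 is estimated at 600 nM, within a range from 150 nM to 2400 nM.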

Compound 3, half-maximal inhibitory concentration: 86 nM
The estimate for compound 3 lay 7.0-fold (0.84 log units) above the measured number, outside the stated range (below it).
By their numbers in this assay, from the lowest: compound 3; then compound 1; then compound 2.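

Read in this assay the replacement of hydrogen by propyl, on a saturated chain carbon five bonds along the chain from an aromatic carbon, gives a 5.0-fold lower number from compound 1 to compound 3 (0.70 log units; beyond the scatter) and so lies beyond the usual scatter. Among the compounds shown here, this is the first change in the set that can be read on its own, and it shows that this position responds to the change and that, for this one pair, the longer chain goes with stronger inhibition. The earlier pair could not give this direction. Those two compounds differ in more than one place. Nothing at hand explains why the number falls with this added propyl.

On these data alone, a single step gives no trend, so it remains open whether a still longer chain would lower the number further, leave it unchanged or raise it again. As far as these compounds go, it is equally open whether a chain ending in an amine, a carboxylic acid or a phenyl ring would keep the stronger inhibition seen with compound 3 at this position.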